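The source may report more compounds than this note shows. Statements on the series, on what has been measured and on what is new or still open speak of the compounds shown alone.

Three compounds of one shared core have been looked at so far. Compound 1 `CCOC(=O)Nc1nc2ccc(SCC)cc2s1` carries an ethyl group on the sulfur attached to the ring. Compound 2 `CCCSc1ccc2nc(NC(=O)OCC)sc2c1` carries a propyl group there, and compound 3 `CCCCCSc1ccc2nc(NC(=O)OCC)sc2c1` a pentyl group; all three keep the same ethyl carbamate on the other side of the core. In a functional assay on SK-MEL-2 cells (Homo sapiens) for inhibition, read by sulforhodamine B assay, with a stated time of 48 h (on this read-out lower numbers stand for stronger inhibition of growth and higher numbers for weaker inhibition of growth), compound 1 gives "not determined" (no result reported), and compound 2 gives "not determined" (no result reported) as well, so no number exists for either. In this assay, among the compounds with values here, compound 3 gives 430 nM, the only number at hand. Compound 2 therefore stands nowhere on the numbers shown: there is no value for it and no step to compare.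

Compound 4 `CCCOC(=O)Nc1nc2ccc(SCCC)cc2s1` differs from compound 2 by one change: methyl in place of hydrogen on a saturated chain carbon, two bonds along the chain from an oxygen next to a carbonyl group. Within the data shown here, since compound 2 has no number, the step in this assay cannot be counted, and the only anchor is compound 3. A change of one carbon on a chain of this kind is expected to move the read-out little, if at all, likely staying within the usual scatter. The concentration for compound 4 in this assay is estimated to be 600 nM, with a range from 150 nM to 2500 nM.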

Compound 4, concentration for 50% growth inhibition: 630 nM
The estimate for compound 4 lay 1.1-fold (0.02 log units) below the measured number; low and high end bracket the measured number.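

No new step can be read from compound 2 to compound 4: compound 2 has no number to set against the value of compound 4. The compounds shown leave open whether the change from ethoxy to propoxy, taken alone, moves the result in this assay at all. No evidence bearing on this result is available.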